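Swapping the amine-bearing ring on a pyrazole chalcone

The source may hold more compounds than are shown below. What is called first, only, known or untested is meant among the compounds shown, and "the series" means these compounds.

Measured compounds, in a functional assay on Malme-3M cells (Homo sapiens) for inhibition, read by sulforhodamine B assay, with a stated time of 48 h; on this read-out lower numbers stand for higher toxicity in this test and higher numbers for lower toxicity in this test:
- compound 1, `COc1ccc(-c2cc(/C=C/C(=O)c3ccc(N)cc3)[nH]n2)cc1`, gives 28800 nM
- compound 2, `COc1cc(-c2cc(/C=C/C(=O)c3ccc(N)cc3)[nH]n2)cc(OC)c1OC`, gives 14400 nM

Compound 2 carries the lowest of the two numbers, and its nearest neighbour is compound 1, whose value lies within the scatter of the same measurement. Nothing can therefore be said about an order between them; both sit in the same region of this assay.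

Compound 3, `COc1cc(-c2cc(/C=C/C(=O)c3ccc(Cl)c(Cl)c3)[nH]n2)cc(OC)c1OC`, is not yet measured. It differs from compound 2 in one place: 3,4-dichlorophenyl in place of 4-aminophenyl on a carbonyl carbon. The rest of the shared core, with its trimethoxyphenyl group on the pyrazole, stays the same.

Going by the values given here, no pair of measured compounds shows what such a swap does in this assay, so the size of the step has to be guessed rather than read off. The expectation for compound 3 is a modest move toward a lower number, close to the edge of the scatter, giving an estimated step of a 1.8-fold lower number from compound 2 to compound 3 (0.26 log units; within the scatter). Compound 3 is thus expected to give about 8000 nM, with a likely range from 2000 nM to 40000 nM.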

Compound 3, concentration lethal to 50% of the cells: > 100000 nM
Compound 3 gave a limit, no number; the forecaster's own chance of this, stated with the estimate: 5%; at least 12-fold (1.09 log units) between middle value and limit.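

In this assay compound 3 gives > 100000 nM, which is a limit of the assay and not a number: the limit of > 100000 nM in this assay, at which 1 of the 3 values shown sits.

Exchanging the 4-aminophenyl group for 3,4-dichlorophenyl, with the rest of the shared core unchanged, gives an at least 6.9-fold higher number from compound 2 to compound 3 (0.84 log units; beyond the scatter), a step that lies beyond the scatter and points toward lower toxicity in this test. Compound 1 and compound 2 both carry 4-aminophenyl at this place, so they could not show that the read-out responds to what sits there; compound 3 shows that it does, and that the response can be large.

The swap removes the amine and brings in two chlorines in a single change, so the compounds shown leave open whether losing the one or gaining the other matters, and how far the true value of compound 3 lies past the limit. A plain phenyl group or a ring bearing a single chlorine at this place would help to separate the two, as would 3,4-dichlorophenyl on the core of compound 1, which has one methoxy group where compound 2 has three.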